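Aryl swap on the amine-linked chain of the sulfonamide series

The compounds below may be only part of what the source reports. "The series", "measured", "known", "first", "only" and "open" are said of these compounds alone.

Among the measured compounds shown here, compound 1 `O=S(=O)(NCCCNCC1COc2ccccc2O1)c1cc(C(F)(F)F)cc(C(F)(F)F)c1` gives 3200 nM in a toxicity assay on MCF-10A cells (Homo sapiens) for inhibition, read by MTT assay, with a stated time of 72 h (a higher number here means a weaker inhibitor of growth, a lower number a stronger inhibitor of growth), the second highest of the three numbers measured so far. For the measured compounds named here, compound 2 `COc1ccc(CNCCCNS(=O)(=O)c2cc(C(F)(F)F)cc(C(F)(F)F)c2)cc1` gives 3100 nM and compound 3 `CC(C)(C)c1ccc(CNCCNS(=O)(=O)c2cc(C(F)(F)F)cc(C(F)(F)F)c2)cc1` gives 14000 nM; between compound 1 and compound 3 no single-place step exists, only the two values as they stand. On these data alone, compound 4 `O=S(=O)(NCCCNCc1ccc(Cl)cc1)c1cc(C(F)(F)F)cc(C(F)(F)F)c1` is untested; its change from compound 1 is 4-chlorophenyl in place of 2,3-dihydro-1,4-benzodioxin-2-yl on a saturated chain carbon bound to an amine nitrogen. Going by the values given here, the one measured step that bears on it is the aryl exchange at the same place, a 1.0-fold lower number from compound 1 to compound 2 (0.01 log units; within the scatter), which stayed within the scatter. A 4-chlorophenyl entering in place of the same leaving group is therefore expected to give a step no larger than the scatter, a 1.1-fold lower number from compound 1 to compound 4 (0.03 log units; within the scatter). Compound 4 is estimated at 3000 nM, with a range from 1500 nM to 7000 nM.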

Compound 4, concentration for 50% growth inhibition: 2300 nM
Compound 4: middle estimate off by 1.3-fold (0.12 log units), on the high side; low and high end bracket the measured number.
By their numbers in this assay, from the lowest: compounds 4, 2 and 1 (each within the scatter of the next); then compound 3.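

The 4-chlorophenyl group, with no hydrogen-bond acceptors against the 2 of the leaving 2,3-dihydro-1,4-benzodioxin-2-yl, still gives only a 1.4-fold lower number from compound 1 to compound 4 (0.14 log units; within the scatter) in this assay, so this place on a saturated chain carbon bound to an amine nitrogen has now taken a second aryl exchange within the scatter. On the aromatic carbon, chloro in place of methoxy adds a 1.3-fold lower number from compound 2 to compound 4 (0.13 log units; within the scatter), also within the scatter. No measurement available here explains these small steps.

Still open, on these data alone, is whether a carboxylic acid or an amine on that aromatic carbon would give a step beyond the scatter. Also open, as far as these compounds go, is whether a non-aromatic group such as cyclohexyl at the chain carbon would do so.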